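The source may report more compounds than this note shows. Statements on the series, on what has been measured and on what is new or still open speak of the compounds shown alone.

Measured so far in a functional assay on HL-60 cells (Homo sapiens), with a stated time of 4 days; on this read-out higher numbers stand for weaker inhibition and lower numbers for stronger inhibition:
- compound 1 `COc1ccc(CNC(=O)c2[nH]cnc2C(=O)Nc2ccc(Cl)c(Cl)c2)cc1` gives 18300 nM
- compound 2 `C[C@@H](NC(=O)c1[nH]cnc1C(=O)Nc1ccc(Cl)c(Cl)c1)C(=O)OC(C)(C)C` gives 2500 nM

Compound 2 holds the lowest of the two numbers and so the strongest inhibition seen; its nearest neighbour is compound 1, with a 7.3-fold lower number from compound 1 to compound 2 (0.86 log units; beyond the scatter) separating them. Compound 3 `C[C@H](NC(=O)c1[nH]cnc1C(=O)Nc1ccc(Cl)c(Cl)c1)C(=O)OC(C)(C)C` is now to be measured in this assay. It differs from compound 2 as follows: the two compounds have the same atoms and bonds and differ only in configuration as drawn: 1 of 1 stereo elements differ; a stereocentre at a saturated chain carbon is drawn R in compound 2 and S in compound 3. Going by the values given here, the one measured step, from compound 1 to compound 2, swapped one group on the amide-type nitrogen for another and was modest in size, but it says nothing about reversing a drawn configuration. Among the compounds with values here, no measured step therefore bears on this change, and the numbers give no direction for it. A mirror-image pair can come out closely similar or far apart. Compound 3 is expected to land near compound 2 with a wide range. The expected step is a 1.4-fold higher number from compound 2 to compound 3 (0.15 log units; within the scatter). The estimate for compound 3 is 3500 nM, expected between 800 nM and 25000 nM.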

Compound 3, half-maximal inhibitory concentration: 2400 nM
For compound 3 the middle estimate is 1.5-fold (0.16 log units) above the measured one, within the range that was stated.
By their numbers in this assay, from the lowest: compounds 3 and 2 (each within the scatter of the next); then compound 1.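

In this assay, reversing the drawn configuration at the saturated chain carbon leaves the read-out unchanged within the scatter (a 1.0-fold lower number from compound 2 to compound 3 (0.02 log units; within the scatter)). This pair isolates that single stereocentre, so at this position and with these groups, its drawn configuration shows no measurable effect on the number: the fact that compounds 2 and 3 differ only in the configuration as drawn. The swap away from 4-methoxybenzyl also gives a similar step with either configuration (a 7.6-fold lower number from compound 1 to compound 3 (0.88 log units; beyond the scatter)), alongside the step already seen (a 7.3-fold lower number from compound 1 to compound 2 (0.86 log units; beyond the scatter)).

From the compounds shown here alone, it remains open whether configuration would still make no difference with another group in place of the tert-butyl ester, such as a free carboxylic acid or a primary amide. Going by these compounds, a longer chain in place of the methyl group on the stereocentre is equally open, and it could show whether that carbon tolerates more than these two mirror-image forms.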